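The source may hold more compounds than are shown below. What is called first, only, known or untested is meant among the compounds shown, and "the series" means these compounds.

Compound 1, `COc1cccc(/C=C/C(=O)c2ccc(OC)c3c2OC(C)(C)C=C3)c1`: in a functional assay on HepG2 cells (Homo sapiens) for antiproliferative activity, read by MTT assay, with a stated time of 24 h (on this read-out higher numbers stand for weaker inhibition and lower numbers for stronger inhibition), compound 1 gives > 10000 nM, a limit of the assay.
Compound 2, `COc1ccc(C(=O)/C=C/c2ccc(F)cc2)c2c1C=CC(C)(C)O2`: in this assay compound 2 gives > 10000 nM, again a limit.
Compound 3, `COc1ccc(C(=O)/C=C/c2cccc([N+](=O)[O-])c2)c2c1C=CC(C)(C)O2`: in this assay compound 3 gives 2830 nM.

Compound 2 thus stands at the limit of > 10000 nM in this assay, at which 2 of the 3 values shown sit, with no number of its own. Compound 4, `COc1ccc(C(=O)/C=C/c2ccccc2)c2c1C=CC(C)(C)O2`, differs from it by hydrogen in place of fluoro on an aromatic carbon. Within the data shown here, no measured step removes fluoro alone: the step that the two limits leave unreadable from compound 1 to compound 2 cannot be sized, and the step of an at least 3.5-fold lower number from compound 2 to compound 3 (0.54 log units; beyond the scatter) exchanges the whole ring substituent. Among the measured compounds shown here, the only readable movement from compound 2 came with nitro. For compound 4 no step beyond the scatter is expected, a step that the limit leaves unreadable from compound 2 to compound 4. Compound 4 is therefore estimated at 12000 nM, within 4000 nM to 40000 nM, most likely again a limit.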

Compound 4, half-maximal inhibitory concentration: > 10000 nM
Compound 4: no number, only a limit; the forecaster's own chance of this, stated with the estimate: 70%; the middle value is on the limit's open side.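

With hydrogen in place of nitro on the aromatic carbon, the result is an at least 3.5-fold higher number from compound 3 to compound 4 (0.54 log units; beyond the scatter), so in this assay the bare phenyl ring does not keep the readable value of compound 3. Compound 4 joins compound 1 and compound 2 at the assay limit, which means the steps among these three cannot be read, including the loss of fluoro: the limit of > 10000 nM in this assay, at which 3 of the 4 values shown sit.

Among the compounds shown, only the nitro compound 3 gives a number. From the compounds shown here alone, whether an amine or a carboxylic acid in place of nitro would also give a number remains open.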